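The source may hold more compounds than are shown below. What is called first, only, known or untested is meant among the compounds shown, and "the series" means these compounds.

Of the compounds shown here, three that share one core have been measured in a functional assay on Molt4/C8 cells (Homo sapiens) for cytotoxicity; on this read-out higher numbers stand for weaker inhibition and lower numbers for stronger inhibition. Compound 1 `O=C(/C=C/C(=O)N1C/C(=C\c2ccccc2)C(=O)/C(=C/c2ccccc2)C1)Nc1ccc(Cl)c(Cl)c1` gives 1700 nM, the highest of the three numbers. Compound 2 `O=C(/C=C/C(=O)N1C/C(=C\c2ccc([N+](=O)[O-])cc2)C(=O)/C(=C/c2ccc([N+](=O)[O-])cc2)C1)Nc1ccc(Cl)c(Cl)c1` gives 600 nM, and compound 3 `O=C(/C=C/C(=O)N1C/C(=C\c2ccc([N+](=O)[O-])cc2)C(=O)/C(=C/c2ccc([N+](=O)[O-])cc2)C1)Nc1ccc([N+](=O)[O-])cc1` gives 430 nM. Compound 4 `Cc1ccc(NC(=O)/C=C/C(=O)N2C/C(=C\c3ccccc3)C(=O)/C(=C/c3ccccc3)C2)cc1` has not yet been measured; it differs from compound 1 by 4-methylphenyl in place of 3,4-dichlorophenyl on an amide-type nitrogen. Going by the values given here, only one measured step touches that same amide-type nitrogen: a 1.4-fold lower number from compound 2 to compound 3 (0.14 log units; within the scatter). Among the compounds with values here, that step brought in a 4-nitrophenyl rather than a 4-methylphenyl, so no measured step shows the 4-methylphenyl itself. With so little to go on, only a small step is expected, a 1.2-fold higher number from compound 1 to compound 4 (0.07 log units; within the scatter), not clearly beyond the usual scatter. Compound 4 is therefore estimated at 2000 nM, with a range from 700 nM to 6000 nM.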

Compound 4, half-maximal inhibitory concentration: 660 nM
The estimate for compound 4 lay 3.0-fold (0.48 log units) above the measured number; measured number below the stated range.
By their numbers in this assay, from the lowest: compounds 3, 2 and 4 (each within the scatter of the next); then compound 1.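

Going by these compounds alone, putting 4-methylphenyl in place of 3,4-dichlorophenyl on the amide-type nitrogen gives a 2.6-fold lower number from compound 1 to compound 4 (0.41 log units; beyond the scatter) and is the first measured change at this position that lies beyond the scatter. Within the data shown here, the only earlier step here, a 1.4-fold lower number from compound 2 to compound 3 (0.14 log units; within the scatter), stayed within the scatter, so changing this group can shift the read-out, at least on the core of compound 1. No measured evidence explains this shift. A plain phenyl or a 4-chlorophenyl on this nitrogen would help separate losing the chlorines from adding the methyl. A 4-methylphenyl on the core of compound 2 would show whether the step carries over.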